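A few compounds are considered here, and "the series" means these few. Any claim that something is new, unique, unknown or untested is made for them only; others in the source may bear on it.

- compound 1 `O=C1CS/C(=N/Nc2nncc3ccccc23)N1c1ccccc1` gives 7.9 nM 
- compound 2 `CCN1C(=O)CS/C1=N/Nc1nncc2ccccc12` gives 0.9 nM 

Of these two, compound 2, at 0.9 nM in a functional assay on SK-OV-3 cells (Homo sapiens) for antiproliferative activity, read by sulforhodamine B assay, with a stated time of 72 h (a lower number here means a stronger inhibitor, a higher number a weaker inhibitor), holds the lower number. Compound 3 `O=C1CS/C(=N/Nc2nncc3ccccc23)N1` carries hydrogen in place of ethyl on an amide-type nitrogen in a ring. Going by the values given here, only one measured step bears on that nitrogen: an 8.8-fold lower number from compound 1 to compound 2 (0.94 log units; beyond the scatter) came with ethyl in place of phenyl. Among the compounds with values here, that step shows the number can move with this group, but no compound with hydrogen there has been measured yet. A modest rise is therefore expected, a 3.3-fold higher number from compound 2 to compound 3 (0.52 log units; beyond the scatter) by this estimate. For compound 3 the estimated value is 3 nM with an expected range of 0.6 nM to 15 nM in this assay.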

Compound 3, half-maximal inhibitory concentration: 0.8 nM
Estimate against measurement, compound 3: 3.8-fold (0.57 log units) above; low and high end bracket the measured number.
By their numbers in this assay, from the lowest: compounds 3 and 2 (each within the scatter of the next); then compound 1.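

Hydrogen and ethyl on this amide-type nitrogen cannot be told apart in this assay (a 1.1-fold lower number from compound 2 to compound 3 (0.05 log units; within the scatter)), so among these compounds, a low number does not depend on having a carbon chain there. Phenyl is the group that stands apart, and replacing it with hydrogen gives a step beyond the scatter (a 9.9-fold lower number from compound 1 to compound 3 (0.99 log units; beyond the scatter)). No measurement shown explains this difference.

Going by these compounds, it remains open how a longer chain such as butyl would behave on this nitrogen. The same question applies to a chain ending in an amine or a carboxylic acid.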